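The source may report more compounds than this note shows. Statements on the series, on what has been measured and on what is new or still open speak of the compounds shown alone.

- compound 1 `CC(=O)N1CCc2c(C)c3c(n2-c2ccc(C(N)=O)c(c2)N[C@@H](C)[C@H](C)C1)CC(C)(C)CC3=O`: 0.333 h
- compound 2 `CC[C@H](N)C(=O)N1CCc2c(C)c3c(n2-c2ccc(C(N)=O)c(c2)N[C@@H](C)[C@H](C)C1)CC(C)(C)CC3=O`: > 0.5 h
- compound 3 `Cc1c2c(n3c1CCN(C(=O)[C@@H](N)C(C)C)C[C@@H](C)[C@H](C)Nc1cc-3ccc1C(N)=O)CC(C)(C)CC2=O`: not yet measured

In an in vitro ADME assay on microsomes (Rattus norvegicus) for metabolic stability (a higher number here means that the compound lasts longer, a lower number that the compound disappears faster), compound 1 gives 0.333 h. Compound 2 gives > 0.5 h, which is a limit of the assay and not a number, so its place can be told only by that limit.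

Compound 3 differs from compound 2 by methyl in place of hydrogen on a saturated chain carbon bound to two saturated chain carbons, which turns 1-aminopropyl into 1-amino-2-methylpropyl.

Among the compounds with values here, only one measured step bears on this change. It is an at least 1.5-fold higher number from compound 1 to compound 2 (0.17 log units; that floor lies within the scatter), where 1-aminopropyl took the place of methyl on a carbonyl carbon. That step is not the same change, and its floor lies within the scatter. With compound 2 known only through > 0.5 h, no step beyond the scatter is expected in this assay, and no direction is favoured. The estimated change is a step that the limit leaves unreadable from compound 2 to compound 3. For compound 3 the half-life is expected to be about 0.55 h, within an estimated range of 0.3 h to 1 h.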

Compound 3, half-life: 0.217 h
For compound 3 the middle estimate is 2.5-fold (0.40 log units) above the measured one, outside the stated range (below it).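

In this assay, methyl in place of hydrogen on a saturated chain carbon bound to two saturated chain carbons gives the one step shown that lies beyond the scatter: an at least 2.3-fold lower number from compound 2 to compound 3 (0.36 log units; beyond the scatter). Turning 1-aminopropyl into 1-amino-2-methylpropyl therefore matters at this place, and the direction is now known, which the earlier pair of compounds could not show; yet measured against methyl on the carbonyl carbon, 1-amino-2-methylpropyl cannot be told apart within the scatter: a 1.5-fold lower number from compound 1 to compound 3 (0.19 log units; within the scatter). The first of these steps can be given only as a floor, because the value of compound 2 is a limit of the assay and not a number: the limit of > 0.5 h in this assay, at which 1 of the 3 values shown sits.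

From the compounds shown here alone, how far compound 2 truly lies past its limit remains open, and with it the full size of the step to compound 3. The compounds shown also leave open whether a longer chain, a cyclopropyl ring or a hydroxyl group at this place would follow the same direction as methyl.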